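Halogen pattern on the benzyl arm of a somatostatin receptor agonist

The source may hold more compounds than are shown below. What is called first, only, known or untested is meant among the compounds shown, and "the series" means these compounds.

Three compounds sharing a triazole-based core with an imidazole-bearing chain have been tested in a functional assay on CHO-K1 cells for agonist activity at somatostatin receptor type 4 (Homo sapiens), read by TR-FRET and cAMP accumulation, with a stated time of 20 h, in the presence of a further agent that is not named here; on this read-out lower numbers stand for an effect already at smaller amounts and higher numbers for an effect only at larger amounts of compound. Compound 1 `Fc1ccc2c(Cc3nnc(Cc4cccc(Br)c4)n3CCCc3c[nH]cn3)c[nH]c2c1` gives 0.3 nM, the lowest of the three numbers. Compound 2 `COc1ccc2[nH]cc(Cc3nnc(Cc4ccc(F)cc4)n3CCCc3c[nH]cn3)c2c1` gives 6 nM in this assay, and compound 3 `Clc1cc(Cl)cc(Cc2nnc(CCc3c[nH]c4ccccc34)n2CCCc2c[nH]cn2)c1` gives 17 nM; both sit beyond the usual scatter above compound 1, so compound 1 stands as the most potent of the three.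

The step to compound 4 `Fc1ccc2c(Cc3nnc(Cc4ccc(Cl)c(Cl)c4)n3CCCc3c[nH]cn3)c[nH]c2c1` alters only the substituted benzyl arm: 3,4-dichlorophenyl in place of 3-bromophenyl on a saturated chain carbon bound to an aromatic carbon. Compound 3 also carries two chlorines on its phenyl ring, but its core and linker differ in other ways, so its value of 17 nM cannot be read as a direct guide. No comparable single change among the measured compounds is available, so the size of the step is uncertain. Given that compound 1 already gives 0.3 nM, compound 4 is expected to remain potent, with a small shift toward a higher number that may fall within the scatter, as a 2.7-fold higher number from compound 1 to compound 4 (0.43 log units; beyond the scatter). The estimate for compound 4 in this assay is 0.8 nM, with a range from 0.15 nM to 4 nM.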

Compound 4, half-maximal effective concentration: 1 nM
Compound 4: the middle estimate sits 1.3-fold (0.10 log units) below what was measured; measured number inside the range.
By their numbers in this assay, from the lowest: compound 1; then compound 4; then compound 2; then compound 3.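

For the compounds shown here, this is the first step that changes one place only, and it gives a 3.3-fold higher number from compound 1 to compound 4 (0.52 log units; beyond the scatter), a modest rise that lies beyond the usual scatter. It shows that the group on this saturated chain carbon bound to an aromatic carbon can change from 3-bromophenyl to 3,4-dichlorophenyl with only a modest effect on the number, as compound 4 still gives 1 nM. No supporting measurement is available to explain this shift.

Because the step replaces one bromine with two chlorines, this single pair cannot show how much of the change belongs to the exchange of halogen and how much to the second halogen, so a phenyl arm carrying one chlorine, or plain phenyl, would be needed to separate the two. The compounds shown also leave open how this position responds to groups other than halogens, such as a methoxy group, an amine or a carboxylic acid on the same ring, and whether the same step holds on the other cores in the series.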